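This account rests on a few compounds, and the source may have more. Where it says the series, first, only, none or still open, it means among the compounds named here.

In a functional assay on MCF7 cells (Homo sapiens) for antiproliferative activity (on this read-out higher numbers stand for weaker inhibition and lower numbers for stronger inhibition), compound 2 `CC(C)=CCc1cc(C(=O)Nc2cc3ccc(OCCCN[C@H](C)c4ccccc4)c(C)c3oc2=O)ccc1O` gives 1450 nM and compound 1 `CC(C)=CCc1cc(C(=O)Nc2cc3ccc(OCCCN(C)C4CCCCC4)c(C)c3oc2=O)ccc1O` gives 1080 nM, so the two sit level, within the usual scatter of each other. Compound 3 `CC(C)=CCc1cc(C(=O)Nc2cc3ccc(OCCCN(C)Cc4ccccc4)c(C)c3oc2=O)ccc1O` keeps the shared core and alters only the amino group at the end of the chain: benzyl(methyl)amino in place of (1-phenylethyl)amino on a saturated chain carbon, three bonds along the chain from an oxygen on an aromatic ring. For the measured compounds named here, the one measured step at this place, a 1.3-fold higher number from compound 1 to compound 2 (0.13 log units; within the scatter), also exchanged one amino group for another and stayed within the scatter. On that evidence alone, no change beyond the scatter is expected, and the estimated step is a 1.2-fold lower number from compound 2 to compound 3 (0.06 log units; within the scatter). The expected value for compound 3 is 1250 nM, with an estimated range of 600 nM to 2600 nM.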

Compound 3, half-maximal inhibitory concentration: 11500 nM
The estimate for compound 3 lay 9.2-fold (0.96 log units) below the measured number, and the stated range ends below it.
By their numbers in this assay, from the lowest: compounds 1 and 2 (each within the scatter of the next); then compound 3.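

Changing to benzyl(methyl)amino gives a 7.9-fold higher number from compound 2 to compound 3 (0.90 log units; beyond the scatter) in this assay and shows that this position is sensitive to which amino group it carries, even with the same heavy atoms. Benzyl in place of cyclohexyl on the amine nitrogen gives an 11-fold higher number from compound 1 to compound 3 (1.03 log units; beyond the scatter) and points the same way. Nothing available explains this loss of activity.

Compound 3 differs from compound 2 in both the amine hydrogen and the placement of the methyl, and these two changes remain unseparated. A benzylamino group, carrying that hydrogen without the methyl, could help to separate them.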